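Phenyl to 3,4-dimethoxyphenyl on a shared core

This account rests on a few compounds, and the source may have more. Where it says the series, first, only, none or still open, it means among the compounds named here.

In a functional assay on MCF7 cells (Homo sapiens) for inhibition, read by sulforhodamine B assay (on this read-out lower numbers stand for stronger inhibition of growth and higher numbers for weaker inhibition of growth), compound 1 (`c1ccc(-c2ccc(-c3ccc(-c4nc5ccccc5[nH]4)cc3)cc2)cc1`) gives 39200 nM and compound 2 (`Clc1cccc(-c2ccc(-c3ccc(-c4nc5ccccc5[nH]4)cc3)cc2)c1`) gives 36300 nM (the two values lie within the scatter of each other). Compound 3 (`COc1ccc(-c2ccc(-c3ccc(-c4nc5ccccc5[nH]4)cc3)cc2)cc1OC`) carries 3,4-dimethoxyphenyl in place of phenyl on an aromatic carbon. Going by the values given here, the only measured step, chloro in place of hydrogen on an aromatic carbon, is a smaller change and gives a 1.1-fold lower number from compound 1 to compound 2 (0.03 log units; within the scatter) (a guide only). No step beyond the scatter is therefore expected in this assay (direction open). The estimated step is a 1.2-fold lower number from compound 1 to compound 3 (0.07 log units; within the scatter) (an expectation only). Compound 3 is expected at 33000 nM (estimated range 15000 nM to 70000 nM).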

Compound 3, concentration for 50% growth inhibition: 7600 nM
For compound 3 the middle estimate is 4.3-fold (0.64 log units) above the measured one, and the stated range ends above it.
By their numbers in this assay, from the lowest: compound 3; then compounds 2 and 1 (each within the scatter of the next).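

Chloro in place of hydrogen had left the number within the scatter, so the earlier compounds showed no response to change at this position in this assay. Going by these compounds alone, the 3,4-dimethoxyphenyl group gives the first step beyond the scatter, a 5.2-fold lower number from compound 1 to compound 3 (0.71 log units; beyond the scatter), and the same holds against the chloro compound, a 4.8-fold lower number from compound 2 to compound 3 (0.68 log units; beyond the scatter). Nothing available bears on the reason for this step. The compounds shown leave open whether a single methoxy group would give the same step, and what an amine or a carboxylic acid would do here.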